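A further fluoro on the aromatic ring of compound 2

The compounds below may be only part of what the source reports. "The series", "measured", "known", "first", "only" and "open" are said of these compounds alone.

Compound 1 `NC(=O)/C=C1\CCc2c(F)cccc21` and compound 2 `NC(=O)/C=C1\CCc2cc(F)ccc21` share one core. In a functional assay on the whole organism with Rattus norvegicus as the target, at a dose of 20 mg/kg by the oral route (a lower number here means less inhibition, a higher number more inhibition at the dose given (going by the name of the read-out)), compound 1 gives 34%, and compound 2 gives 42%. Compound 2 holds the higher of the two numbers, but its gap to compound 1 lies within the usual scatter, so the two cannot be ordered. Compound 3 `NC(=O)/C=C1\CCc2c1ccc(F)c2F` carries a further fluoro group: fluoro in place of hydrogen on an aromatic carbon. Among the measured compounds shown here, no step between measured compounds is known, so the size of the change in this assay is open. A modest upward step is expected, a number 6 percentage points higher from compound 2 to compound 3 (within the scatter). Compound 3 is estimated to give 48% in this assay, between 30% and 66%.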

Compound 3, a percentage reported as inhibition, in the whole organism at one dose (the size of the read-out at that dose, not a potency): 82%
Estimate against measurement, compound 3: 34 percentage points below, and the stated range ends below it.
By their numbers in this assay, from the lowest: compounds 1 and 2 (each within the scatter of the next); then compound 3.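

In this assay a fluoro in place of hydrogen on this aromatic carbon, ortho to a fluoro group, gives a number 40 percentage points higher from compound 2 to compound 3 (beyond the scatter) and a number 48 percentage points higher from compound 1 to compound 3 (beyond the scatter) even though compound 1 and compound 2 could not be ordered. The earlier compounds shown here, with one fluoro each, did not show that this read-out could respond so strongly to a change of a single atom. Nothing measured here bears on the reason for the step. As far as these compounds go, whether a chloro or a methoxy at this carbon would give a similar number stays open, as does the effect of a carboxylic acid in place of the amide in compound 3.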